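The compounds below may be only part of what the source reports. "The series", "measured", "known", "first", "only" and "open" are said of these compounds alone.

Measured in a functional assay on MCF7 cells (Homo sapiens) for antiproliferative activity, read by MTT assay, with a stated time of 72 h; a higher number here means a weaker inhibitor, a lower number a stronger inhibitor:
- compound 1 `CCCCCCCCCCNC[C@@H]1OC[C@H](N)[C@@H]1O`: 34200 nM
- compound 2 `CCCCCCCCCNC[C@@H]1OC[C@H](N)[C@H]1O`: 60300 nM
- compound 3 `CCCCCCCCCCCNC[C@@H]1OC[C@H](N)[C@H]1O`: 13100 nM

Compound 1 lies within the usual scatter of compound 2, and its number is higher than that of compound 3, beyond the scatter. Compound 4 `CCCCCCCCCCCCCCNC[C@@H]1OC[C@H](N)[C@@H]1O` differs from compound 1 as follows: butyl in place of hydrogen on a saturated chain carbon, ten or more bonds along the chain from an amine nitrogen. For the measured compounds named here, the only measured step that bears on this is modest: a 4.6-fold lower number from compound 2 to compound 3 (0.66 log units; beyond the scatter), for ethyl in place of hydrogen on a saturated chain carbon, nine bonds along the chain from an amine nitrogen. That pair has a core differing in configuration from compound 1, so it is an imperfect guide. A somewhat larger step in the same direction is expected in this assay, estimated as a 5.7-fold lower number from compound 1 to compound 4 (0.76 log units; beyond the scatter). The estimate for compound 4 is 6000 nM, with an expected range of 2000 nM to 16000 nM.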

Compound 4, half-maximal inhibitory concentration: 720 nM
Beside the measured number, compound 4's estimate is 8.3-fold (0.92 log units) above it; the whole stated range lies above it.
By their numbers in this assay, from the lowest: compound 4; then compound 3; then compounds 1 and 2 (each within the scatter of the next).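

In this assay, butyl in place of hydrogen on a saturated chain carbon, ten or more bonds along the chain from an amine nitrogen, gives a 48-fold lower number from compound 1 to compound 4 (1.68 log units; beyond the scatter), a large step. This is the first chain change shown on the core of compound 1, and it exceeds a 4.6-fold lower number from compound 2 to compound 3 (0.66 log units; beyond the scatter), a modest step on a core differing in configuration. Nothing available accounts for the size of this step. From the compounds shown here alone, whether a longer chain than that of compound 4 would lower the number further remains open, as does how the same butyl change would behave on the core of compound 2.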